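Re-joining the same atoms on the amide nitrogen

The source may hold more compounds than are shown below. What is called first, only, known or untested is meant among the compounds shown, and "the series" means these compounds.

Measured so far:
- compound 1, `CCN(Cc1cccs1)C(=O)COc1ccc(C)cc1`: in an assay on HEK293 cells for agonist activity at transient receptor potential cation channel subfamily M member 8 (Homo sapiens), read by fluorescence and calcium flux, with a stated time of 15 min (on this read-out lower numbers stand for an effect already at smaller amounts and higher numbers for an effect only at larger amounts of compound), compound 1 gives 8 nM
- compound 2, `Cc1ccc(OCC(=O)N(Cc2cccs2)c2ncco2)cc1`: compound 2 gives 0.3 nM
- compound 3, `Cc1ccc(OCC(=O)N(Cc2cccs2)c2nccn2C)cc1`: compound 3 gives 1790 nM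

Compound 3 has the highest number of the three; the nearest is compound 1, with a 220-fold higher number from compound 1 to compound 3 (2.35 log units; beyond the scatter), and the furthest is compound 2, with a 6000-fold higher number from compound 2 to compound 3 (3.78 log units; beyond the scatter). Compound 4, `Cc1ccc(OCC(=O)N(Cc2cccs2)c2c[nH]nc2C)cc1`, differs from compound 3 only at the amide-type nitrogen: 3-methyl-1H-pyrazol-4-yl in place of 1-methyl-1H-imidazol-2-yl on an amide-type nitrogen.

Both measured steps that touch this position bear on the change. Putting 1,3-oxazol-2-yl on that nitrogen gave a 27-fold lower number from compound 1 to compound 2 (1.43 log units; beyond the scatter), while 1-methyl-1H-imidazol-2-yl gave a 220-fold higher number from compound 1 to compound 3 (2.35 log units; beyond the scatter), so the group on this nitrogen moves the read-out over a very wide span in either direction. Since the new group in compound 4 is neither of those two, its number is expected to fall between the extremes, most likely an improvement on compound 3, a 9.0-fold lower number from compound 3 to compound 4 (0.95 log units; beyond the scatter). Compound 4 is therefore estimated at 200 nM, with a range from 20 nM to 3000 nM.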

Compound 4, half-maximal effective concentration: 0.4 nM
The estimate for compound 4 lay 500-fold (2.70 log units) above the measured number, outside the stated range (below it).
By their numbers in this assay, from the lowest: compounds 2 and 4 (each within the scatter of the next); then compound 1; then compound 3.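

The two groups carry the same atoms and each is one five-membered aromatic ring with 2 hetero atoms, yet re-joining them in this assay gave a 4500-fold lower number from compound 3 to compound 4 (3.65 log units; beyond the scatter) and so showed that, on this amide-type nitrogen, how the atoms are joined can outweigh which atoms are present. The result also gave a 1.3-fold higher number from compound 2 to compound 4 (0.12 log units; within the scatter) and a 20-fold lower number from compound 1 to compound 4 (1.30 log units; beyond the scatter) in the same assay, so two different rings can match each other here and both improve on the ethyl group, while 1-methyl-1H-imidazol-2-yl does not. Nothing given here explains this large difference between the two arrangements.

From the compounds shown here alone, it remains open whether the hydrogen-bond donor that enters with 3-methyl-1H-pyrazol-4-yl matters for this result. Also open, going by these compounds, is whether 1H-imidazol-2-yl, lacking the methyl group, would behave like its methylated form or like the 3-methyl-1H-pyrazol-4-yl group.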